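A Hydroxymethyl Added to a Thromboxane Receptor Antagonist

A few compounds are considered here, and "the series" means these few. Any claim that something is new, unique, unknown or untested is made for them only; others in the source may bear on it.

Compound 1 `O=C(O)CC/C=C\CO[C@H]1C(OCc2ccc(-c3ccccc3)cc2)CC[C@@H]1N1CCCCCC1` is measured in a functional assay on blood for antagonist activity at thromboxane A2 receptor (Homo sapiens) (on this read-out lower numbers stand for tighter binding and higher numbers for weaker binding), where compound 1 gives 12.6 nM. Of the two single numbers in this assay, compound 1 has the lowest; compound 2 `O=C(O)CC/C=C\CO[C@@H]1C(OCc2ccc(-c3ccccc3)cc2)CC[C@@H]1N1CCCCC1` gives 39.8 nM, and the gap between them lies beyond the scatter. Compound 3 `O=C(O)CC/C=C\CO[C@H]1C(OCc2ccc(-c3ccccc3)cc2)CC[C@@H]1N1CCCCC1` has several entries, giving 63.1 nM; 15.9 nM (2 entries), as shown by the several entries of compound 3 in this assay, 63.1 nM; 15.9 nM (2 entries).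

Compound 4 `O=C(O)CC/C=C\CO[C@H]1C(OCc2ccc(-c3ccc(CO)cc3)cc2)CC[C@@H]1N1CCCCCC1` has not yet been measured. It differs from compound 1 by hydroxymethyl in place of hydrogen on an aromatic carbon. For the measured compounds named here, no measured pair shows this change, so the expected step from compound 1 to compound 4 is a 1.2-fold higher number from compound 1 to compound 4 (0.08 log units; within the scatter), a change within the scatter. Compound 4 is therefore estimated at 15 nM, within a range of 5 nM to 45 nM.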

Compound 4, dissociation constant: 3.16 nM
Estimate against measurement, compound 4: 4.7-fold (0.68 log units) above, outside the stated range (below it).
By their numbers in this assay, from the lowest: compound 4; then compound 1; then compound 2.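

Changing phenyl to 4-(hydroxymethyl)phenyl gives a 4.0-fold lower number from compound 1 to compound 4 (0.60 log units; beyond the scatter) in this assay, so this aromatic carbon takes a hydroxymethyl group with a gain rather than a loss. For the compounds shown here, the earlier compounds all carry the same unsubstituted outer phenyl ring, so this is the first view of that end of the molecule. Nothing in the data shown accounts for the size of this step.

As far as these compounds go, whether the gain needs the oxygen or only the added carbon remains open. A methyl group or a carboxylic acid at the same place would begin to separate the two.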